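This account rests on a few compounds, and the source may have more. Where it says the series, first, only, none or still open, it means among the compounds named here.

Measured so far in a functional assay on SW-620 cells (Homo sapiens) for inhibition; on this read-out higher numbers stand for weaker inhibition and lower numbers for stronger inhibition:
- compound 1 `CCN1C(=O)NC2(CSC3=C2C(=O)c2ccccc2C3=O)C1=O`: 203 nM
- compound 2 `O=C1C2=C(C(=O)c3ccccc31)C1(CS2)NC(=O)N(CCO)C1=O`: 198 nM
- compound 3 `NCCN1C(=O)NC2(CSC3=C2C(=O)c2ccccc2C3=O)C1=O`: 35 nM; 34 nM; 47 nM (3 entries)

Among the compounds with values here, compound 2 holds the lower of the two single numbers in this assay, but the only measured step, a 1.0-fold lower number from compound 1 to compound 2 (0.01 log units; within the scatter), lies within the scatter, so compound 1 and compound 2 cannot be ordered against each other. Compound 3 gives 35 nM; 34 nM; 47 nM (3 entries); its repeated entries, (the several entries of compound 3 in this assay, 35 nM; 34 nM; 47 nM (3 entries)), agree closely with one another and sit clearly below the numbers of compound 1 and compound 2.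

Compound 4 `NCCCN1C(=O)NC2(CSC3=C2C(=O)c2ccccc2C3=O)C1=O` differs from compound 2 by aminomethyl in place of hydroxy on a saturated chain carbon, two bonds along the chain from an amide-type nitrogen in a ring. Within the data shown here, no measured step covers this exact change. Compound 3 carries the 2-aminoethyl chain and compound 4 the 3-aminopropyl chain, so the values of compound 3 are the closest guide, while the step of a 1.0-fold lower number from compound 1 to compound 2 (0.01 log units; within the scatter) shows the hydroxy in place of hydrogen made no difference. Compound 4 is therefore expected to move toward the numbers of compound 3, a step of about a 4.0-fold lower number from compound 2 to compound 4 (0.60 log units; beyond the scatter) in this assay. The estimate for compound 4 is 50 nM, expected to fall between 20 nM and 150 nM.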

Compound 4, half-maximal inhibitory concentration: 52 nM
Compound 4: the middle estimate sits 1.0-fold (0.02 log units) below what was measured, and the stated range covers the measured number.
By their numbers in this assay, from the lowest: compound 4; then compounds 2 and 1 (each within the scatter of the next).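

In this assay, the step from hydrogen to hydroxy had left the numbers within the scatter, whereas aminomethyl at this chain carbon gives a clear change: a 3.8-fold lower number from compound 2 to compound 4 (0.58 log units; beyond the scatter), and a 3.9-fold lower number from compound 1 to compound 4 (0.59 log units; beyond the scatter). The lower numbers are thus not confined to the 2-aminoethyl chain of compound 3, since the 3-aminopropyl chain of compound 4 also stands apart from compound 1 and compound 2, and no compound shown goes against this. Compound 4 gives 52 nM, and the nearest numbers in the series are these: the several entries of compound 3 in this assay, 35 nM; 34 nM; 47 nM (3 entries).

Open, from the compounds shown here alone, is whether a dimethylamino group or a carboxylic acid in place of the amine, or a longer chain such as 4-aminobutyl, would hold these numbers. The compounds shown also do not tell whether the lower numbers carry over to other cell lines.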